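This account rests on a few compounds, and the source may have more. Where it says the series, first, only, none or still open, it means among the compounds named here.

Compound 2 `CCOC(=O)Nc1ccc([Se]C#N)cc1` stands highest of the three numbers measured in an ADME assay on BEAS-2B cells (Homo sapiens) for cytotoxicity, read by MTT assay, with a stated time of 72 h; a higher number here means a weaker inhibitor of growth, a lower number a stronger inhibitor of growth: compound 2 gives 21700 nM. Its nearest neighbour is compound 1 `C=CCOC(=O)Nc1ccc([Se]C#N)cc1`, which in this assay gives 21400 nM, a number within the scatter of that of compound 2. Compound 3 `N#C[Se]c1ccc(NC(=O)Oc2ccc(Cl)cc2)cc1`, which differs from compound 2 in more than one place, sits furthest away; in this assay compound 3 gives 9300 nM, a lower number than compound 2 by a margin beyond the scatter.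

Compound 4 `CCCCCCOC(=O)Nc1ccc([Se]C#N)cc1` has not been measured. It differs from compound 2 in one place: butyl in place of hydrogen on a saturated chain carbon, two bonds along the chain from an oxygen next to a carbonyl group. Within the data shown here, only one measured step bears on it, a 1.0-fold higher number from compound 1 to compound 2 (0.01 log units; within the scatter), a change on the same chain that left the number unmoved. That step concerns a small exchange on the chain carbon bound to the oxygen rather than a lengthening of the chain by butyl, so it guides only loosely. On that basis compound 4 is expected to show a 1.4-fold lower number from compound 2 to compound 4 (0.16 log units; within the scatter), a step not clearly beyond the scatter. The estimate for compound 4 is 15000 nM, with a range from 5000 nM to 40000 nM.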

Compound 4, concentration for 50% growth inhibition: 2800 nM
Estimate against measurement, compound 4: 5.4-fold (0.73 log units) above; the whole stated range lies above it.
By their numbers in this assay, from the lowest: compound 4; then compound 3; then compounds 1 and 2 (each within the scatter of the next).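

In this assay, butyl in place of hydrogen on the saturated chain carbon, two bonds along the chain from an oxygen next to a carbonyl group, gives a 7.8-fold lower number from compound 2 to compound 4 (0.89 log units; beyond the scatter). This shows that the chain can move the number well beyond the scatter, which the earlier exchange, a 1.0-fold higher number from compound 1 to compound 2 (0.01 log units; within the scatter), did not reveal. The second route to the same hexyl chain agrees: pentyl in place of vinyl on the saturated chain carbon bound to an oxygen next to a carbonyl group gives a 7.6-fold lower number from compound 1 to compound 4 (0.88 log units; beyond the scatter), also beyond the scatter.

From the compounds shown here alone, whether a longer chain such as octyl, or a branched one such as isopropyl, would carry the number further down or back up remains open. Nothing given here accounts for the size of this step.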